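The source may hold more compounds than are shown below. What is called first, only, known or untested is meant among the compounds shown, and "the series" means these compounds.

Going by the values given here, in an ADME assay on MT4 cells (Homo sapiens) for cytotoxicity, read by MTT assay, with a stated time of 5 days (a higher number here means that more compound is tolerated, a lower number that less compound is tolerated), compound 2 `O=[N+]([O-])c1ccc(-c2nnc(-c3cccnc3)n2Nc2nc3ccc([N+](=O)[O-])cc3s2)cc1` gives 50.8 ug/mL, the only exact number available so far. Compound 1 `O=[N+]([O-])c1ccc(-c2nnc(-c3cccnc3)n2Nc2nc3ccc(F)cc3s2)cc1` reports >= 108 ug/mL, and this value is a limit. Compound 3 `O=[N+]([O-])c1ccc(-c2nnc(-c3cccnc3)n2Nc2nc3ccc(Cl)cc3s2)cc1` keeps the shared core and differs from compound 2 at one site: chloro in place of nitro on an aromatic carbon. Among the compounds with values here, only one measured step bears on this change, an at least 2.1-fold lower number from compound 1 to compound 2 (0.32 log units; beyond the scatter), where nitro took the place of fluoro on an aromatic carbon. From the compounds shown here alone, that step involves fluoro rather than chloro, so it offers only an indirect guide, and its true size remains open. Since compound 3 also loses the nitro, a shift in the opposite direction to that step is expected. The estimated step is a 1.8-fold higher number from compound 2 to compound 3 (0.25 log units; within the scatter), toward a higher number in this assay. For compound 3 the expected value is 90 ug/mL, with an estimated range from 42 ug/mL to 150 ug/mL.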

Compound 3, half-maximal cytotoxic concentration: 53.7 ug/mL
The estimate for compound 3 lay 1.7-fold (0.22 log units) above the measured number; the measured number falls inside the stated range.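

In this assay, the change at this aromatic carbon gives a 1.1-fold higher number from compound 2 to compound 3 (0.02 log units; within the scatter), so chloro and nitro are not told apart here, and the loss of the nitro alone does not separate compound 3 from compound 2. Chloro in place of fluoro gives an at least 2.0-fold lower number from compound 1 to compound 3 (0.30 log units; that floor lies within the scatter), a floor that, unlike the one for nitro in place of fluoro, does not clear the scatter. The value of compound 1 is a limit and not a number, so neither comparison with it has a known size: the limit of >= 108 ug/mL in this assay, at which 1 of the 3 values shown sits.

From the compounds shown here alone, whether fluoro truly stands apart from chloro and nitro at this carbon remains open, as compound 1 has no exact number. Going by these compounds, how an amine, a methoxy group or a carboxylic acid at this carbon would read in this assay also remains open.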